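The source may report more compounds than this note shows. Statements on the series, on what has been measured and on what is new or still open speak of the compounds shown alone.

Three compounds were measured in a functional assay on SW480 cells (Homo sapiens) for inhibition, read by luminescence and resazurin assay, with a stated time of 3 days; on this read-out higher numbers stand for weaker inhibition and lower numbers for stronger inhibition:

- Compound 1 `CCCNc1nc(NCc2ccc(C(=O)NCc3ccc(F)cc3)cc2)c2cc(C)ccc2n1` gives 2200 nM
- Compound 2 `Cc1ccc2nc(N3CCNC(C)C3)nc(NCc3ccc(C(=O)NCc4ccc(F)cc4)cc3)c2c1` gives 1400 nM
- Compound 3 `CNc1ncc(C)c(NCc2ccc(NC(=O)c3ccc(F)cc3)cc2)n1` gives > 20000 nM, which is a limit of the assay

For the measured compounds named here, compound 2 holds one of only two numbers, and the other belongs to compound 1. The step between them is a 1.6-fold lower number from compound 1 to compound 2 (0.20 log units; within the scatter).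

Compound 4 `Cc1ccc2nc(N(C)C)nc(NCc3ccc(C(=O)NCc4ccc(F)cc4)cc3)c2c1` carries dimethylamino in place of 3-methylpiperazin-1-yl on an aromatic carbon. Going by the values given here, the only measured step at this place is the one from compound 1 to compound 2, a 1.6-fold lower number from compound 1 to compound 2 (0.20 log units; within the scatter). Among the compounds with values here, compound 3 offers no step to this change. In this assay no change beyond the scatter is therefore expected, and the expected step is a 1.3-fold higher number from compound 2 to compound 4 (0.11 log units; within the scatter). For compound 4 the estimated value is 1800 nM, with an expected range from 700 nM to 5000 nM.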

Compound 4, half-maximal inhibitory concentration: 1100 nM
Compound 4: middle estimate off by 1.6-fold (0.21 log units), on the high side; low and high end bracket the measured number.
By their numbers in this assay, from the lowest: compounds 4, 2 and 1 (each within the scatter of the next). At a limit, above all of these: compound 3.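

In this assay, the place between two ring nitrogen atoms now has three different groups, and none separates from another: a 1.3-fold lower number from compound 2 to compound 4 (0.10 log units; within the scatter), and a 2.0-fold lower number from compound 1 to compound 4 (0.30 log units; within the scatter). Dimethylamino, with no ring and 0 hydrogen-bond donors, thus reads within the scatter of the 3-methylpiperazin-1-yl it replaces, so neither that ring nor its hydrogen-bond donor is needed here. Nothing shown gives a reason for this flat reading.

Going by these compounds, whether a carboxylic acid or a longer amine such as hexylamino at this place would move the number beyond the scatter remains open.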